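The source may report more compounds than this note shows. Statements on the series, on what has been measured and on what is new or still open speak of the compounds shown alone.

Measured so far:
- compound 1, `Cc1cc(NC(=O)Nc2cccc(Cl)c2)c2ccccc2n1`: 566 10^-6 cm/s
- compound 2, `Cc1cc(NC(=O)Nc2cccc(C(N)=O)c2)c2ccccc2n1`: 2 10^-6 cm/s
- compound 3, `Cc1cc(NC(=O)Nc2cccc([N+](=O)[O-])c2)c2ccccc2n1`: 42 10^-6 cm/s

All three share one core and differ only in the group on the outer aromatic ring. In an ADME assay for permeability, using PAMPA, at pH 7.4 (a higher number here means that the compound crosses the layer faster, a lower number that the compound crosses the layer more slowly), compound 3 stands second highest of the three: it is separated from compound 1 by a 13-fold lower number from compound 1 to compound 3 (1.13 log units; beyond the scatter) and from compound 2 by a 21-fold higher number from compound 2 to compound 3 (1.32 log units; beyond the scatter), so both neighbours lie beyond the scatter from it. Compound 4, `COc1cccc(NC(=O)Nc2cc(C)nc3ccccc23)c1`, is the next step from compound 3: methoxy in place of nitro on an aromatic carbon. Among the compounds with values here, no measured step shows the methoxy group itself, so the nearest guide is how the nitro group behaved. Putting the nitro in place of chloro gave a 13-fold lower number from compound 1 to compound 3 (1.13 log units; beyond the scatter), and putting it in place of carbamoyl gave a 21-fold higher number from compound 2 to compound 3 (1.32 log units; beyond the scatter); the nitro therefore sits between those two in this assay. Taking the nitro away again is expected to move the number back toward compound 1, so a rise of roughly a 6.0-fold higher number from compound 3 to compound 4 (0.77 log units; beyond the scatter) is expected. Compound 4 is estimated at 250 10^-6 cm/s, within a range from 80 10^-6 cm/s to 600 10^-6 cm/s.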

Compound 4, apparent permeability: 818 10^-6 cm/s
Compound 4: middle estimate off by 3.3-fold (0.51 log units), on the low side, and the stated range ends below it.
By their numbers in this assay, from the lowest: compound 2; then compound 3; then compounds 1 and 4 (each within the scatter of the next).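

In this assay, methoxy on this aromatic carbon, meta to a large group, lies far from nitro (a 19-fold higher number from compound 3 to compound 4 (1.29 log units; beyond the scatter)) and further still from carbamoyl (a 410-fold higher number from compound 2 to compound 4 (2.61 log units; beyond the scatter)), yet it cannot be told apart from chloro (a 1.4-fold higher number from compound 1 to compound 4 (0.16 log units; within the scatter)). Chloro is therefore not alone at the high end: compound 1 and compound 4 stand together, well apart from compound 2 and compound 3, although their groups share no atoms. The swap is small by count, with nitro leaving at 3 heavy atoms and methoxy entering at 2, but the number still moves a long way, so a small exchange here can matter greatly. Nothing given here explains why these groups fall as they do. Going by these compounds, how an amine, a carboxylic acid or a longer chain such as ethoxy would behave at this position remains open.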